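From ethoxycarbonyl to acetyl in compound 3

This account rests on a few compounds, and the source may have more. Where it says the series, first, only, none or still open, it means among the compounds named here.

Compound 1 `CCOC(=O)c1ccc(Nc2nnc(Cl)c(Nc3cc(OC)c(OC)c(OC)c3)n2)cc1` gives 58500 nM
Compound 2 `COc1cc(Nc2nc(Nc3ccc4c(ccn4C)c3)nnc2Cl)cc(OC)c1OC` gives 48500 nM

In a functional assay on PC-3 cells (Homo sapiens) for inhibition, read by MTT assay, with a stated time of 48 h (on this read-out higher numbers stand for weaker inhibition and lower numbers for stronger inhibition), compound 1 gives 58500 nM and stands level with compound 2 at 48500 nM within the scatter, so the two cannot be ranked. Compound 3 `COc1cc(Nc2nc(Nc3ccc(C(C)=O)cc3)nnc2Cl)cc(OC)c1OC` has methyl in place of ethoxy on a carbonyl carbon, ethoxycarbonyl to acetyl methyl in place of ethoxy on a carbonyl carbon with the rest of compound 1 unchanged. For the measured compounds named here, no measured step speaks to this change, so no step beyond the scatter is expected in this assay in either direction. The estimated 1.5-fold lower number from compound 1 to compound 3 (0.17 log units; within the scatter) is expected to stay small. For compound 3 the expected value is 40000 nM with an estimated range from 15000 nM to 90000 nM for repeated measurements.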

Compound 3, half-maximal inhibitory concentration: 38600 nM
Beside the measured number, compound 3's estimate is 1.0-fold (0.02 log units) above it; low and high end bracket the measured number.
By their numbers in this assay, from the lowest: compounds 3, 2 and 1 (each within the scatter of the next).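

In this assay, methyl in place of ethoxy on a carbonyl carbon gives a 1.5-fold lower number from compound 1 to compound 3 (0.18 log units; within the scatter), so the change from ethoxycarbonyl to acetyl stays within the scatter at this position. Likewise, 4-acetylphenyl in place of 1-methyl-1H-indol-5-yl on a nitrogen on an aromatic ring gives a 1.3-fold lower number from compound 2 to compound 3 (0.10 log units; within the scatter), so neither exchange separates the compounds. No supporting data bear on these results. The compounds shown leave open whether an amine or a longer chain on that carbonyl carbon would give a step beyond the scatter.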